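Pyrazin-2-yl for Pyridin-2-yl in Antiproliferative Compounds

The source may report more compounds than this note shows. Statements on the series, on what has been measured and on what is new or still open speak of the compounds shown alone.

All numbers below come from a functional assay on U-937 cells (Homo sapiens) for antiproliferative activity, read by CCK-8 assay, with a stated time of 24 h; a higher number here means a weaker inhibitor, a lower number a stronger inhibitor.

Compound 1 `C/C(=N\NC(=O)Nc1nc2ccc(CN(C)C)cc2s1)c1ccccn1` gives 20100 nM.
Compound 2 `C/C(=N\NC(=O)Nc1nc2ccc(CN(C)C)cc2s1)c1cnccn1` reaches only a limit of the assay, > 40000 nM.
Compound 3 `C/C(=N\NC(=O)Nc1ccc(CN2CCC(C)CC2)cc1)c1ccccn1` likewise reaches only a limit of the assay, > 40000 nM.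

Compound 1 and compound 2 share one core and differ in a single place: pyrazin-2-yl in place of pyridin-2-yl on a carbon with a double bond to nitrogen. That change gave an at least 1.9-fold higher number from compound 1 to compound 2 (0.29 log units; that floor lies within the scatter), and its true size cannot be fixed because of the limit of > 40000 nM in this assay, at which 2 of the 3 values shown sit. Compound 3 carries a different core, and how the two cores differ is not broken down here.

Compound 4 `C/C(=N\NC(=O)Nc1ccc(CN2CCC(C)CC2)cc1)c1cnccn1` is not yet measured. It stands to compound 3 as compound 2 stands to compound 1: pyrazin-2-yl in place of pyridin-2-yl on a carbon with a double bond to nitrogen. The surroundings of the changed position are the same in both pairs, so this is the same change. Since compound 3 already sits at the limit in this assay, > 40000 nM, and the earlier step went toward weaker inhibition, compound 4 is expected to show a step that the limit leaves unreadable from compound 3 to compound 4, most likely again reported only as a limit. The estimate for compound 4 is 60000 nM, within 30000 nM to 150000 nM.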

Compound 4, half-maximal inhibitory concentration: > 40000 nM
Compound 4 gave a limit, no number; the forecaster's own chance of this, stated with the estimate: 85%; the middle value does not contradict the limit.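

Compound 3 and compound 4 both stop at a limit in this assay, so no size or direction can be read for the step between them: the limit of > 40000 nM in this assay, at which 3 of the 4 values shown sit.

The compounds shown leave open how large the effect of pyrazin-2-yl in place of pyridin-2-yl truly is on either core, and whether it is the same on both.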